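The source may hold more compounds than are shown below. What is called first, only, known or untested is meant among the compounds shown, and "the series" means these compounds.

Measured so far in a functional assay on the whole organism (strain Wistar) with Rattus norvegicus as the target, read by paw edema; on this read-out higher numbers stand for an effect only at larger amounts of compound and lower numbers for an effect already at smaller amounts:
compound 1 `CCCC(=O)NS(=O)(=O)c1ccc(-n2nc(C(F)(F)F)cc2-c2ccc(C)cc2)cc1` gives 6.64 mg/kg 
compound 2 `CCC(=O)OCc1cc(-n2nc(C(F)(F)F)cc2-c2ccc(SC)cc2)ccc1S(N)(=O)=O` gives 60 mg/kg 
compound 3 `CCC(=O)NS(=O)(=O)c1ccc(-n2nc(C(F)(F)F)cc2-c2ccc(Br)cc2)cc1CO` gives 7.2 mg/kg 

Compound 2 stands highest of these three numbers: at 60 mg/kg it lies beyond the usual scatter from both of the others. Compound 4 `CCC(=O)OCc1cc(-n2nc(C(F)(F)F)cc2-c2ccc3c(c2)CCO3)ccc1S(N)(=O)=O` keeps all of compound 2 except one group, and the change is a group of 9 heavy atoms (8 carbon, 1 oxygen; one five-membered non-aromatic ring with 1 hetero atom, one six-membered aromatic ring of carbon only) in place of a group of 8 heavy atoms (7 carbon, 1 sulfur; one six-membered aromatic ring of carbon only), on an aromatic carbon on an aromatic carbon of a five-membered aromatic ring with 2 nitrogen. The 4-(methylsulfanyl)phenyl leaves, and a group with one five-membered non-aromatic ring and one six-membered aromatic ring of carbon only enters.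

For the measured compounds named here, no measured pair shows this change alone, as compounds 1 and 3 also differ from compound 2 elsewhere. The lower numbers of compound 1 at 6.64 mg/kg and compound 3 at 7.2 mg/kg therefore pull the expectation down only slightly. In this assay the expected step is small and toward a lower number, with none clearly beyond the scatter, and the estimated step is a 1.5-fold lower number from compound 2 to compound 4 (0.18 log units; within the scatter) in size. For compound 4 the estimated value is 40 mg/kg, with an expected range from 12 mg/kg to 120 mg/kg.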

Compound 4, dose for half-maximal effect: 8.5 mg/kg
Beside the measured number, compound 4's estimate is 4.7-fold (0.67 log units) above it; measured number outside the range, below it.
By their numbers in this assay, from the lowest: compounds 1, 3 and 4 (each within the scatter of the next); then compound 2.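

In this assay, the replacement of the 4-(methylsulfanyl)phenyl by the group with one five-membered non-aromatic ring and one six-membered aromatic ring of carbon only gives a 7.1-fold lower number from compound 2 to compound 4 (0.85 log units; beyond the scatter). For the compounds shown here, this is the first single-place comparison, and it shows that the number responds to the group held on this aromatic carbon of the five-membered aromatic ring with 2 nitrogen, which compounds 1 and 3 could not show, as each also differs from compound 2 elsewhere. The two groups have the same counts of hydrogen-bond donors and acceptors, no net charge and nearly the same number of heavy atoms, so these counts do not separate them, and nothing measured here accounts for the step.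

From the compounds shown here alone, whether the oxygen or the non-aromatic ring of the entering group carries the step stays open, as does the reading of a phenyl bearing a methoxy group, an amine or a carboxylic acid at this position. Going by these compounds, it is also open whether the same exchange would give a step of this size on the core of compound 1 or of compound 3.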